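Moving one methoxy group: what to expect for compound 3

The compounds below may be only part of what the source reports. "The series", "measured", "known", "first", "only" and "open" are said of these compounds alone.

- Compound 1 `COc1cc(/C=C/C(=O)/C=C/c2cc(OC)c(OC)c(OC)c2)ccc1OCc1cn(CCOc2cc(=O)oc3ccccc23)nn1` (820 nM)
- Compound 2 `COc1ccccc1/C=C/C(=O)/C=C/c1ccc(OCc2cn(CCOc3cc(=O)oc4ccccc34)nn2)c(OC)c1` (7330 nM)

In a functional assay on THP-1 cells (Homo sapiens) for cytotoxicity, read by sulforhodamine B assay, with a stated time of 48 h (a lower number here means a stronger inhibitor, a higher number a weaker inhibitor), compound 2 has the higher of the two numbers (7330 nM) and is therefore the weaker inhibitor of the pair. Compound 3 `COc1ccc(/C=C/C(=O)/C=C/c2ccc(OCc3cn(CCOc4cc(=O)oc5ccccc45)nn3)c(OC)c2)cc1` is not yet measured and differs from compound 2 at one place: 4-methoxyphenyl in place of 2-methoxyphenyl on a double-bonded chain carbon bound to a double-bonded chain carbon. Going by the values given here, the only measured step at this place is an 8.9-fold higher number from compound 1 to compound 2 (0.95 log units; beyond the scatter). Among the compounds with values here, that step swaps the same group, but no measured compound carries 4-methoxyphenyl, so only a modest step toward a lower number is expected, and with wide uncertainty. The expected change is a 2.1-fold lower number from compound 2 to compound 3 (0.32 log units; beyond the scatter). For compound 3 the estimated value is 3500 nM, with an expected range from 1000 nM to 11000 nM.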

Compound 3, half-maximal inhibitory concentration: 7410 nM
For compound 3 the middle estimate is 2.1-fold (0.33 log units) below the measured one; the measured number falls inside the stated range.
By their numbers in this assay, from the lowest: compound 1; then compounds 2 and 3 (each within the scatter of the next).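

In this assay, going by these compounds alone, 4-methoxyphenyl in place of 2-methoxyphenyl gives a 1.0-fold higher number from compound 2 to compound 3 (0.00 log units; within the scatter), so at this chain carbon the two placements of the single methoxy group cannot be told apart. Compared with 3,4,5-trimethoxyphenyl, 4-methoxyphenyl gives a 9.0-fold higher number from compound 1 to compound 3 (0.96 log units; beyond the scatter), so among these three compounds only compound 1 stands apart. No measurement shown here explains this result.

On these data alone, it remains open whether compound 1 stands apart through the number of methoxy groups or through one particular group. A plain phenyl or an aminophenyl at this place could help settle that.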